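Amide nitrogen substituent and cytotoxicity in the shared core

This account rests on a few compounds, and the source may have more. Where it says the series, first, only, none or still open, it means among the compounds named here.

Compound 3 `C=CC1=C(C(=O)Nc2ccccc2OC)C(c2ccc(OC)cc2)OC1` stands at the ceiling of a functional assay on SW480 cells (Homo sapiens) for cytotoxicity, read by MTT assay, with a stated time of 24 h; on this read-out higher numbers stand for weaker inhibition and lower numbers for stronger inhibition: compound 3 gives > 100000 nM, which is a limit of the assay and not a number. Compound 1 `C=CC1=C(C(=O)NC(C)(C)C)C(c2ccc(OC)cc2)OC1` likewise gives only a limit in this assay, > 100000 nM. For the measured compounds named here, compound 2 `C=CC1=C(C(=O)NCc2ccc(C)cc2)C(c2ccc(OC)cc2)OC1` gives 31700 nM, the sole number in the set. The situation is summed up by the limit of > 100000 nM in this assay, at which 2 of the 3 values shown sit. Compound 4 `C=CC1=C(C(=O)Nc2ccc(C)cc2)C(c2ccc(OC)cc2)OC1` differs from compound 3 by 4-methylphenyl in place of 2-methoxyphenyl on an amide-type nitrogen. Going by the values given here, no measured step exchanges one aryl group for another on the amide nitrogen. The nearest are an at least 3.1-fold higher number from compound 2 to compound 3 (0.49 log units; beyond the scatter) and an at least 3.1-fold lower number from compound 1 to compound 2 (0.49 log units; beyond the scatter), both involving 4-methylbenzyl, which shares its methyl-bearing ring with the 4-methylphenyl that enters; the step that the two limits leave unreadable from compound 1 to compound 3 cannot be read from two limits. On that basis a modest lowering of the number from compound 3 to compound 4 is expected, an at least 1.6-fold lower number from compound 3 to compound 4 (0.22 log units; that floor lies within the scatter), with a real chance that only the limit is reported again. Compound 4 is estimated at 60000 nM, expected to fall between 20000 nM and 200000 nM.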

Compound 4, half-maximal inhibitory concentration: > 100000 nM
Compound 4: a limit, no number; the forecaster's own chance of this, stated with the estimate: 45%; at least 1.6-fold (0.22 log units) between middle value and limit.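

In this assay compound 4 gives > 100000 nM, which is a limit of the assay and not a number. Exchanging 4-methylbenzyl for 4-methylphenyl on the amide-type nitrogen gives an at least 3.1-fold higher number from compound 2 to compound 4 (0.49 log units; beyond the scatter), so the methyl-bearing ring alone does not keep the value in the readable range in this set. Steps between two limits cannot be read, and the series remains bounded by a single ceiling: the limit of > 100000 nM in this assay, at which 3 of the 4 values shown sit.

Open, as far as these compounds go, is whether an unsubstituted benzyl, a 4-methoxybenzyl or a 2-phenylethyl group on the amide nitrogen would give a number in this assay, which would show whether the result for compound 2 is specific to 4-methylbenzyl. Also open, from the compounds shown here alone, is how far compound 1, compound 3 and compound 4 lie past the limit, and whether any order exists among them.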